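Cyclohexyl in Place of Butyl on the Sulfonyl Sulfur

This account rests on a few compounds, and the source may have more. Where it says the series, first, only, none or still open, it means among the compounds named here.

Compound 1 `CC(C)NC(=O)CN1CCN(c2ccc(OCC3CCN(C(=O)OC(C)C)CC3)cn2)CC1`: in a functional assay on CHO-K1 cells for agonist activity at Glucose-dependent insulinotropic receptor (Homo sapiens), read by a luciferase reporter, with a stated time of 5 h (on this read-out lower numbers stand for an effect already at smaller amounts and higher numbers for an effect only at larger amounts of compound), compound 1 gives only the limit > 10000 nM.
Compound 2 `CC(C)OC(=O)N1CCC(COc2ccc(N3CCN(C(=O)c4ccco4)CC3)nc2)CC1`: in this assay compound 2 gives 1900 nM.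
Compound 3 `CCCCS(=O)(=O)N1CCN(c2ccc(OCC3CCN(C(=O)OC(C)C)CC3)cn2)CC1`: in this assay compound 3 gives 100 nM.

Compound 3 stands lowest of the two numbers, with compound 2 nearest (a 19-fold lower number from compound 2 to compound 3 (1.28 log units; beyond the scatter)); compound 1 sits at a limit (the limit of > 10000 nM in this assay, at which 1 of the 3 values shown sits). Compound 4 `CC(C)OC(=O)N1CCC(COc2ccc(N3CCN(S(=O)(=O)C4CCCCC4)CC3)nc2)CC1` differs from compound 3 by cyclohexyl in place of butyl on a sulfonyl sulfur. The measured steps (an at least 100-fold lower number from compound 1 to compound 3 (2.00 log units; beyond the scatter), a 19-fold lower number from compound 2 to compound 3 (1.28 log units; beyond the scatter), an at least 5.2-fold lower number from compound 1 to compound 2 (0.72 log units; beyond the scatter)) all exchange the whole group on the ring nitrogen and keep the sulfonyl once it appears; none alters the carbon group on the sulfonyl sulfur, so they bear on this step only indirectly. Compound 4 is therefore expected to stay close to compound 3, the expected step of a 1.1-fold higher number from compound 3 to compound 4 (0.04 log units; within the scatter) lying within the scatter. The estimate for compound 4 in this assay is 110 nM, between 30 nM and 450 nM.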

Compound 4, half-maximal effective concentration: 200 nM
The estimate for compound 4 lay 1.8-fold (0.26 log units) below the measured number; the range from low to high includes it.
By their numbers in this assay, from the lowest: compounds 3 and 4 (each within the scatter of the next); then compound 2. At a limit, above all of these: compound 1.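

In this assay, the step of a 2.0-fold higher number from compound 3 to compound 4 (0.30 log units; within the scatter) shows that this position on the sulfonyl sulfur accepts a six-membered carbon ring as well as the butyl chain, with no change beyond the scatter. Cyclohexylsulfonyl also keeps the advantage over the other groups on the ring nitrogen, with a 9.5-fold lower number from compound 2 to compound 4 (0.98 log units; beyond the scatter) and an at least 50-fold lower number from compound 1 to compound 4 (1.69 log units; beyond the scatter). The value of compound 1 is a limit and not a number: the limit of > 10000 nM in this assay, at which 1 of the 4 values shown sits.

Going by these compounds, it stays open whether a longer chain, a phenyl ring or an amine on the sulfonyl sulfur would hold this level.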